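This account rests on a few compounds, and the source may have more. Where it says the series, first, only, none or still open, it means among the compounds named here.

Measured compounds:
compound 1 `Cc1nc(C(F)(F)F)ccc1CNC(=O)C(C)c1ccc(NS(C)(=O)=O)c(F)c1`, 387 nM
compound 2 `CC(C)=Cc1nc(C(F)(F)F)ccc1CNC(=O)C(C)c1ccc(NS(C)(=O)=O)c(F)c1`, 11.5 nM

For the measured compounds named here, in an assay on CHO cells for antagonist activity at transient receptor potential cation channel subfamily V member 1 (Homo sapiens), read by FLIPR and calcium flux (a lower number here means a stronger inhibitor, a higher number a weaker inhibitor), compound 2 holds the lowest of the two numbers; the only other is compound 1, and the step of a 34-fold lower number from compound 1 to compound 2 (1.53 log units; beyond the scatter) is large. Compound 3 `CCC/C=C\c1nc(C(F)(F)F)ccc1CNC(=O)C(C)c1ccc(NS(C)(=O)=O)c(F)c1` differs from compound 2 by pent-1-en-1-yl in place of 2-methylprop-1-en-1-yl on an aromatic carbon. Going by the values given here, only the step of a 34-fold lower number from compound 1 to compound 2 (1.53 log units; beyond the scatter) bears on this change, and it went from a methyl to an alkenyl group; exchanging one alkenyl group for another is expected to give a 1.3-fold higher number from compound 2 to compound 3 (0.12 log units; within the scatter), nothing beyond the scatter. Compound 3 is therefore estimated at 15 nM in this assay, between 4 nM and 60 nM.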

Compound 3, inhibition constant: 2.1 nM
The estimate for compound 3 lay 7.1-fold (0.85 log units) above the measured number, and the stated range ends above it.
By their numbers in this assay, from the lowest: compound 3; then compound 2; then compound 1.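

At this position next to the ring nitrogen, the two alkenyl groups are not interchangeable in this assay: pent-1-en-1-yl in place of 2-methylprop-1-en-1-yl gives a 5.5-fold lower number from compound 2 to compound 3 (0.74 log units; beyond the scatter) and so counts as a modest change. Pent-1-en-1-yl in place of methyl gives a 180-fold lower number from compound 1 to compound 3 (2.27 log units; beyond the scatter) as the largest step in the set, so the size of the gain over methyl depends on which alkenyl group enters. Nothing available explains the difference between these two groups. From the compounds shown here alone, whether the double bond matters stays open, as a saturated pentyl chain would test that. Going by these compounds, how an amine or a phenyl ring at this position would compare also remains open.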